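Fluoro removal at weak inhibition levels in a biaryl series

The source may report more compounds than this note shows. Statements on the series, on what has been measured and on what is new or still open speak of the compounds shown alone.

Compound 1 `Fc1ccc(-c2ccc(Cn3ccnc3)cc2)cn1` gives 4% in an assay for inhibition of steroid 17-alpha-hydroxylase/17,20 lyase (Homo sapiens), using NADPH, tested at 0.2 uM; on this read-out lower numbers stand for a weaker effect and higher numbers for a stronger effect at the one concentration tested. Compound 2 `c1cncc(-c2ccc(Cn3ccnc3)cc2)c1` gives 2% in this assay, and the step of a number 2 percentage points lower from compound 1 to compound 2 (within the scatter) comes from hydrogen in place of fluoro on an aromatic carbon. Compound 3 `Fc1ccc(-c2csc(Cn3ccnc3)c2)cc1F` gives 7% in this assay; how its core differs from that of compound 1 is not broken down here. Compound 4 `Fc1ccc(-c2csc(Cn3ccnc3)c2)cc1` is not yet measured and differs from compound 3 by hydrogen in place of fluoro on an aromatic carbon. This is the same kind of change as in the pair of compounds 1 and 2, not the same: there the fluoro sat on a six-membered aromatic ring with one nitrogen, next to the ring nitrogen and para to a large group; here it sits on a six-membered aromatic ring of carbon only, ortho to a fluoro group and meta to a large group. The step of a number 2 percentage points lower from compound 3 to compound 4 (within the scatter) is expected to be small, resting on the step of a number 2 percentage points lower from compound 1 to compound 2 (within the scatter) from compound 1 to compound 2, which stayed within the scatter. For compound 4 the estimate in this assay is 5%, expected between 0% and 13%.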

Compound 4, a percentage reported as inhibition, at one concentration (the size of the read-out at that concentration, not a potency): 0%
For compound 4 the middle estimate is 5 percentage points above the measured one; measured number inside the range.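

Hydrogen in place of fluoro on an aromatic carbon gives a number 7 percentage points lower from compound 3 to compound 4 (within the scatter) in this assay, so the change stays small on this core too. The two steps do not differ on the two cores: the same change on two cores in this assay, a number 2 percentage points lower (within the scatter) from compound 1 to compound 2 and a number 7 percentage points lower (within the scatter) from compound 3 to compound 4, 5 percentage points apart, within the scatter of two such steps

This supports carrying the change between these two cores only as a step that stays within the scatter. It does not fix a size or direction for the change, and with so little inhibition at the one concentration tested, it does not show how the change would behave on a compound with a stronger effect.

The compounds shown carry only fluoro or hydrogen at the changed place. From the compounds shown here alone, whether a nitrile or an amine there would move the read-out beyond the scatter on either core remains open.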